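Acetyl to (2-chlorophenyl)carbonyl swap on a shared amide core

A few compounds are considered here, and "the series" means these few. Any claim that something is new, unique, unknown or untested is made for them only; others in the source may bear on it.

Measured in a functional assay on NCI-H23 cells (Homo sapiens) for cytotoxicity, read by sulforhodamine B assay, with a stated time of 72 h; on this read-out lower numbers stand for stronger inhibition of growth and higher numbers for weaker inhibition of growth:
- compound 1, `O=C(Nc1cc(C(F)(F)F)cc(C(F)(F)F)c1)C1CCc2ccccc2N1C(=O)c1ccccc1Cl`, gives 2080 nM
- compound 2, `CC(=O)N1c2ccccc2CCC1C(=O)Nc1cc(C(F)(F)F)cc(C(F)(F)F)c1`, is recorded only as an assay limit, > 70000 nM
- compound 3, `CC(=O)N1c2ccccc2CCC1C(=O)Nc1ccccc1C(F)(F)F`, is recorded only as an assay limit, > 80000 nM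

Compound 2 and compound 1 differ in one place, (2-chlorophenyl in place of methyl on a carbonyl carbon), and in this assay this gave an at least 33-fold lower number from compound 2 to compound 1 (1.52 log units; beyond the scatter). How the core of compound 2 differs from the core of compound 3 is not broken down here.

Compound 4, `O=C(Nc1ccccc1C(F)(F)F)C1CCc2ccccc2N1C(=O)c1ccccc1Cl`, is not yet measured. It differs from compound 3 by 2-chlorophenyl in place of methyl on a carbonyl carbon, at a place described in the same words as for compound 2 and compound 1, so it is the same change. Compound 3 only reached the assay limit, so the starting point of the step is open. Compound 4 is therefore expected to move by about an at least 10-fold lower number from compound 3 to compound 4 (1.00 log units; beyond the scatter), an expectation resting on an at least 33-fold lower number from compound 2 to compound 1 (1.52 log units; beyond the scatter) and on the limit of compound 3, > 80000 nM. In this assay compound 4 is estimated at 8000 nM, between 1500 nM and 60000 nM.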

Compound 4, concentration for 50% growth inhibition: 2150 nM
Beside the measured number, compound 4's estimate is 3.7-fold (0.57 log units) above it; the measured number falls inside the stated range.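

In this assay, replacing methyl with 2-chlorophenyl on the carbonyl carbon held by the ring amide nitrogen again gave a large step, an at least 37-fold lower number from compound 3 to compound 4 (1.57 log units; beyond the scatter), so the direction of the change seen on the first core also held on the second. Set side by side, the two steps read: the same change on two cores in this assay, an at least 33-fold lower number (1.52 log units; beyond the scatter) from compound 2 to compound 1 and an at least 37-fold lower number (1.57 log units; beyond the scatter) from compound 3 to compound 4; the limit leaves it open whether they differ. Compound 3 is recorded only as a limit, > 80000 nM, so its step has a minimum size and no exact one, and the two cores show that the direction carries over, not that the size does.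

The compounds shown leave open whether the step depends on the chlorine or on the aromatic ring, since they do not include a plain phenyl at this place. They also leave open how an amine, a carboxylic acid or a longer alkyl chain on this carbonyl carbon would read in this assay.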